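Sulfonyl capping of the ring amine and loss of activity

This account rests on a few compounds, and the source may have more. Where it says the series, first, only, none or still open, it means among the compounds named here.

Three compounds share one core and differ only in what sits on the amine nitrogen of the six-membered ring with two nitrogens. Compound 1 `COC(=O)c1ccc(C2SCC(=O)N2c2ccc(N3CCN(Cc4cccc(C)c4)CC3)cn2)c(OC)c1` carries a 3-methylbenzyl group there; in a functional assay on K562 cells (Homo sapiens) for antiproliferative activity, read by MTT assay and trypan blue exclusion, with a stated time of 72 h (a higher number here means a weaker inhibitor, a lower number a stronger inhibitor), compound 1 reaches only a limit of the assay, > 100000 nM. Compound 2 `COC(=O)c1ccc(C2SCC(=O)N2c2ccc(N3CCN(S(=O)(=O)c4ccc(F)cc4)CC3)cn2)c(OC)c1`, with a (4-fluorophenyl)sulfonyl group, likewise reaches only a limit in this assay, > 100000 nM. The step that the two limits leave unreadable from compound 1 to compound 2 therefore cannot be read. Among the measured compounds shown here, compound 3 `COC(=O)c1ccc(C2SCC(=O)N2c2ccc(N3CCNCC3)cn2)c(OC)c1`, the free amine, is the only one with a measured number; in this assay compound 3 gives 15200 nM, so it stands as the sole readable point among the three. The steps of an at least 6.5-fold lower number from compound 1 to compound 3 (0.81 log units; beyond the scatter) and an at least 6.5-fold lower number from compound 2 to compound 3 (0.81 log units; beyond the scatter) both run in the same direction, and their size is bounded only because of the limit of > 100000 nM in this assay, at which 2 of the 3 values shown sit.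

Compound 4 `COC(=O)c1ccc(C2SCC(=O)N2c2ccc(N3CCN(S(=O)(=O)c4ccc(OC)cc4)CC3)cn2)c(OC)c1` is not yet measured. It differs from compound 3 by (4-methoxyphenyl)sulfonyl in place of hydrogen on an amine nitrogen in a ring. The closest measured step is the reverse of an at least 6.5-fold lower number from compound 2 to compound 3 (0.81 log units; beyond the scatter), where a sulfonyl on the amine nitrogen in the ring sat at the limit. The step of a 7.9-fold higher number from compound 3 to compound 4 (0.90 log units; beyond the scatter) is therefore expected to raise the number, most likely into the region where the assay reports only a limit. Compound 4 is estimated at 120000 nM, within 40000 nM to 300000 nM.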

Compound 4, half-maximal inhibitory concentration: 54500 nM
Estimate against measurement, compound 4: 2.2-fold (0.34 log units) above; the measured number falls inside the stated range.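

Among the compounds shown here, with compound 4, a sulfonyl group on this amine nitrogen gives a measured number in this assay for the first time, so the cost of capping the ring amine can be sized rather than only bounded: the step is a 3.6-fold higher number from compound 3 to compound 4 (0.55 log units; beyond the scatter). A sulfonyl on this nitrogen therefore does not by itself carry a compound to the limit of the assay, although the free amine of compound 3 remains the lower number of this readable pair. The two other new steps, an at least 1.8-fold lower number from compound 2 to compound 4 (0.26 log units; that floor lies within the scatter) and an at least 1.8-fold lower number from compound 1 to compound 4 (0.26 log units; that floor lies within the scatter), have floors inside the scatter, so neither the change from fluoro to methoxy nor the change from 3-methylbenzyl to (4-methoxyphenyl)sulfonyl can be given a real size, because their true ends are hidden: the limit of > 100000 nM in this assay, at which 2 of the 4 values shown sit.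

The compounds shown leave open how far the aromatic substituent on the sulfonyl group matters, since a chloro group or a carboxylic acid in its place would test this directly. They also leave open whether a smaller cap on the same nitrogen, such as methanesulfonyl or acetyl, would stay closer to compound 3.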